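Removing the Methyl from Sulfur: What to Expect

The source may hold more compounds than are shown below. What is called first, only, known or untested is meant among the compounds shown, and "the series" means these compounds.

Of the compounds shown here, three have been measured in a functional assay on MCF7 cells (Homo sapiens) for cytotoxicity, read by MTT assay, with a stated time of 72 h; a higher number here means a weaker inhibitor of growth, a lower number a stronger inhibitor of growth.
Compound 1 `COc1ccc(CNc2nc([Se]C)nc3ccccc23)cc1` gives 42200 nM
Compound 2 `Sc1nc(NCc2ccccc2)c2ccccc2n1` gives 27200 nM
Compound 3 `COc1ccc(CNc2nc(SC)nc3ccccc23)cc1` gives 30900 nM

Compound 3 stands second highest of these three numbers, yet its gaps to compound 2 and to compound 1 both lie within the scatter, so the three cannot be told apart. Among the compounds with values here, the only single-point step measured, a 1.4-fold lower number from compound 1 to compound 3 (0.14 log units; within the scatter), is also within the scatter.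

Compound 4 `COc1ccc(CNc2nc(S)nc3ccccc23)cc1` differs from compound 3 by hydrogen in place of methyl on a sulfur. Within the data shown here, no measured step reproduces this change. The closest guide is compound 2, which also carries a sulfanyl group and sits within the scatter of compound 3. Compound 4 is therefore expected to show a 1.0-fold lower number from compound 3 to compound 4 (0.01 log units; within the scatter), nothing beyond the scatter. The estimate for compound 4 is 30000 nM, ranging from 12000 nM to 75000 nM.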

Compound 4, concentration for 50% growth inhibition: 7080 nM
Compound 4: the middle estimate sits 4.2-fold (0.63 log units) above what was measured; the measured number lies below the stated range.
By their numbers in this assay, from the lowest: compound 4; then compounds 2, 3 and 1 (each within the scatter of the next).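

Within the data shown here, on a sulfur attached to an aromatic carbon, the methyl matters: hydrogen in its place gives the first step here that lies beyond the scatter (a 4.4-fold lower number from compound 3 to compound 4 (0.64 log units; beyond the scatter)). The sulfanyl group alone does not set the result, since methoxy in place of hydrogen on an aromatic carbon also counts (a 3.8-fold lower number from compound 2 to compound 4 (0.58 log units; beyond the scatter)). Sulfanyl in place of the selenium-bearing group gives a step of similar kind (a 6.0-fold lower number from compound 1 to compound 4 (0.78 log units; beyond the scatter)).

On these data alone, whether an ethyl group or an amine at this place would behave like methyl or like hydrogen stays open. Nothing available gives a cause for these steps.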